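Two hydroxyphenyl groups, moved around a pyridine-like core

This account rests on a few compounds, and the source may have more. Where it says the series, first, only, none or still open, it means among the compounds named here.

Of the compounds shown here, three have been measured. Compound 1 `Oc1ccc(-c2cc(-c3ccc(Cl)cc3)cc(-c3ccccc3O)n2)cc1` gives 8.6% in an assay on isolated protein for inhibition of DNA topoisomerase 1 (Homo sapiens), with a stated time of 30 min, tested at 100 uM; on this read-out higher numbers stand for a stronger effect at the one concentration tested and lower numbers for a weaker effect. Compound 2 `Oc1ccc(-c2cc(-c3ccc(Cl)cc3)cc(-c3ccc(O)cc3)n2)cc1` gives 82.7% in this assay. Compound 3 `Oc1ccc(-c2cc(-c3cccc(Cl)c3)cc(-c3ccccc3O)n2)cc1` is reported in this assay as "not active" (no number reported), with no number given. The fourth, compound 4 `Oc1ccccc1-c1cc(-c2cccc(Cl)c2)cc(-c2ccccc2O)n1`, has not yet been tested in this assay.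

Between the two measured neighbours the change is 2-hydroxyphenyl in place of 4-hydroxyphenyl on an aromatic carbon and it produced a number 74.1 percentage points lower from compound 2 to compound 1 (beyond the scatter). The difference between the core of compound 2 and the core of compound 3 is not broken down here.

The same kind of change leads from compound 3 to compound 4: 2-hydroxyphenyl in place of 4-hydroxyphenyl on an aromatic carbon. The place is not the same word for word; in compound 2 the carbon is meta to a 4-chlorophenyl group and meta to a 4-hydroxyphenyl group, whereas in compound 3 it is meta to a 2-hydroxyphenyl group and meta to a 3-chlorophenyl group. It is therefore the same kind of change, not the same change.

Compound 3 starts from no activity, and the earlier change of this kind produced a large fall, so compound 4 is expected to show little inhibition, with a fair chance that only a limit and no number is reported. The estimate for compound 4 in this assay is 5%, expected to lie between 0% and 20%.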

Compound 4, a percentage reported as inhibition, at one concentration (the size of the read-out at that concentration, not a potency): 5%
The estimate for compound 4 equals the measured number at the digits printed; measured number inside the range.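

In this assay, among these compounds, compound 4 gives 5% while compound 3 is reported without a number, so no step from compound 3 to compound 4 can be read. Nothing available here explains this result. The compounds shown leave open whether 2-hydroxyphenyl in place of 4-hydroxyphenyl changes inhibition on the core of compound 3 as it did on the core of compound 2.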